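Swapping 2-hydroxyphenyl for 4-methoxyphenyl on the shared core

A few compounds are considered here, and "the series" means these few. Any claim that something is new, unique, unknown or untested is made for them only; others in the source may bear on it.

Values measured in a functional assay on PANC-1 cells (Homo sapiens) for inhibition, read by MTT assay, with a stated time of 24 h (a higher number here means a weaker inhibitor, a lower number a stronger inhibitor), so far
- compound 1 `CC1(C)[C@H]2CC[C@]1(C)N(Cc1cn(-c3ccccc3Br)nn1)C(=O)C2` gives 280 nM
- compound 2 `CC1(C)[C@H]2CC[C@]1(C)N(Cc1cn(-c3ccccc3O)nn1)C(=O)C2` gives 230 nM

These two numbers lie within the usual scatter of each other, so compound 2 cannot be ranked against compound 1 on this evidence. The next structure is compound 3 `COc1ccc(-n2cc(CN3C(=O)C[C@@H]4CC[C@@]3(C)C4(C)C)nn2)cc1`. It differs from compound 2 as follows (4-methoxyphenyl in place of 2-hydroxyphenyl on an aromatic nitrogen). In words, 4-methoxyphenyl stands in place of 2-hydroxyphenyl on an aromatic nitrogen.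

Among the measured compounds shown here, only one measured step bears on this change. It is a 1.2-fold lower number from compound 1 to compound 2 (0.09 log units; within the scatter), where hydroxy replaced bromo on an aromatic carbon, and it stayed within the scatter. That step shows that one swap on this aromatic ring left the number within the scatter, but it is weak evidence. For the measured compounds named here, no measured compound carries a 4-methoxyphenyl group, so no direct test of this group exists.

A step beyond the scatter is therefore not expected in this assay, and no direction can be argued with confidence. The estimate amounts to a 1.2-fold higher number from compound 2 to compound 3 (0.09 log units; within the scatter), an expected change that stays within the scatter. For compound 3 the expected value is 280 nM, with an estimated range from 110 nM to 700 nM.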

Compound 3, half-maximal inhibitory concentration: 330 nM
Beside the measured number, compound 3's estimate is 1.2-fold (0.07 log units) below it; the range from low to high includes it.
By their numbers in this assay, from the lowest: compounds 2, 1 and 3 (each within the scatter of the next).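

In this assay, among the compounds shown here, this is the first reading of a 4-methoxyphenyl group on this aromatic nitrogen, and replacing 2-hydroxyphenyl with it gives a 1.4-fold higher number from compound 2 to compound 3 (0.16 log units; within the scatter) as the measured step. The hydrogen-bond donor count of the group goes from 1 to 0 in this swap, yet the number stays within the scatter, and the comparison with the bromo compound reads the same way, with a 1.2-fold higher number from compound 1 to compound 3 (0.07 log units; within the scatter) as its step. Among these three compounds, then, changing the group on this ring has produced no readable difference, and no supporting measurement is available to explain that result.

The 4-methoxyphenyl group differs from 2-hydroxyphenyl both in its substituent and in where that substituent stands, so a 2-methoxyphenyl or a 4-hydroxyphenyl group would be needed to tell those two changes apart. As far as these compounds go, it also remains open whether a clearly different group on this ring, such as an amine, a carboxylic acid or a longer chain like butoxy in place of methoxy, would move the number beyond the scatter.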